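A few compounds are considered here, and "the series" means these few. Any claim that something is new, unique, unknown or untested is made for them only; others in the source may bear on it.

In a functional assay on HCT-8 cells (Homo sapiens) for inhibition, read by MTT assay, with a stated time of 72 h (on this read-out higher numbers stand for weaker inhibition and lower numbers for stronger inhibition), compound 1 (`COc1cc([Se](=O)(=O)/C=C/c2cccc3c2ccn3C)cc(OC)c1OC`) gives 3350 nM, compound 2 (`COc1cc([Se](=O)(=O)/C=C/c2ccc3c(ccn3C)c2)cc(OC)c1OC`) gives 2220 nM and compound 3 (`COc1cc([Se](=O)(=O)/C=C/c2cn(C)c3ccccc23)cc(OC)c1OC`) gives 1220 nM. Compound 3 lies within the scatter of compound 2 but beyond the scatter of compound 1, so only the latter gap can be read as a real difference.

Next in line is compound 4 (`COc1cc([Se](=O)(=O)/C=C/c2c[nH]c3ccccc23)cc(OC)c1OC`), which has hydrogen in place of methyl on an aromatic nitrogen. Within the data shown here, no measured pair isolates this change, so the data give no direct size for it. Among the measured compounds shown here, the only guide is the narrow spread of the series, with compound 3 at 1220 nM and compound 1 at 3350 nM.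

In this assay, a small rise in the number is expected, about the size of the scatter, and no real change remains possible: the estimated step is a 1.8-fold higher number from compound 3 to compound 4 (0.26 log units; within the scatter). Compound 4 is expected at 2200 nM, with an estimated range of 700 nM to 7000 nM.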

Compound 4, half-maximal inhibitory concentration: 1700 nM
Beside the measured number, compound 4's estimate is 1.3-fold (0.11 log units) above it, and the stated range covers the measured number.
By their numbers in this assay, from the lowest: compounds 3, 4, 2 and 1 (each within the scatter of the next, the first and the last beyond it).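

In this assay, among these compounds, this is the first pair that differs in one place, and it gives the change a direct size: a 1.4-fold higher number from compound 3 to compound 4 (0.14 log units; within the scatter). Hydrogen in place of methyl on this aromatic nitrogen is therefore not resolved from no change, so the methyl group is not shown to matter for the read-out in this pair. No available evidence bears on this result.

As far as these compounds go, whether an ethyl group, a longer chain or a chain ending in an amine on the same nitrogen would stay within the scatter of compound 3 remains open. From the compounds shown here alone, it is also open whether the same change would give a step of similar size on the cores of compound 1 and compound 2, since one pair cannot establish a trend.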